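Replacing the (trifluoromethyl)sulfanyl group of compound 3 with chloro

The source may report more compounds than this note shows. Statements on the series, on what has been measured and on what is new or still open speak of the compounds shown alone.

Among the compounds with values here, in an ADME assay on HEK293 cells (Homo sapiens) for cytotoxicity, with a stated time of 72 h (on this read-out lower numbers stand for an effect already at smaller amounts and higher numbers for an effect only at larger amounts of compound), compound 3 `Cc1cc(NC(=O)Nc2ccc(SC(F)(F)F)cc2)c2ccccc2n1` gives 13000 nM, the only actual number so far. Compound 1 `Cc1cc(NC(=O)Nc2ccc(Cl)c(Cl)c2)c2ccccc2n1` reports only a limit, > 25000 nM. Compound 2 `Cc1cc(NC(=O)Nc2ccc(O)cc2)c2ccccc2n1` likewise reports only a limit, > 25000 nM. Compound 4 `Cc1cc(NC(=O)Nc2ccc(Cl)cc2)c2ccccc2n1` carries chloro in place of (trifluoromethyl)sulfanyl on an aromatic carbon. Within the data shown here, the one measured step that bears on this change is an at least 1.9-fold lower number from compound 2 to compound 3 (0.28 log units; that floor lies within the scatter), where the same group entered in place of hydroxy. Among the measured compounds shown here, with that step as the only guide, no step beyond the scatter is expected in this assay, at most a slight drift towards higher numbers. The expected change is a 1.5-fold higher number from compound 3 to compound 4 (0.19 log units; within the scatter). The estimate for compound 4 is 20000 nM, within a range of 10000 nM to 38000 nM.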

Compound 4, half-maximal effective concentration: > 25000 nM
Compound 4 ended at the assay's limit; the forecaster's own chance of this, stated with the estimate: 50%; middle value at least 1.2-fold (0.09 log units) away from the limit.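

In this assay, chloro in place of (trifluoromethyl)sulfanyl at this position gives an at least 1.9-fold higher number from compound 3 to compound 4 (0.28 log units; that floor lies within the scatter), so this change, like the hydroxy change, shows no step beyond the scatter. The steps to compound 4 from compound 1 and from compound 2 cannot be read, with limits at both ends. With chloro at this position, compound 4 also sits at the limit, leaving compound 3 as the only compound with a number: the limit of > 25000 nM in this assay, at which 3 of the 4 values shown sit.

As far as these compounds go, how far compound 1, compound 2 and compound 4 lie past that limit stays open. So does whether an amine or a carboxylic acid at this position would give a number.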